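The source may report more compounds than this note shows. Statements on the series, on what has been measured and on what is new or still open speak of the compounds shown alone.

Among the compounds with values here, the three compounds measured so far share one core. Compound 1 `CN1Cc2c(N)cccc2C(c2ccc(Cl)cc2)C1` is the most active of them: in a functional assay on the whole organism for inhibition of sodium-dependent dopamine transporter (Mus musculus) (on this read-out higher numbers stand for an effect only at larger amounts of compound and lower numbers for an effect already at smaller amounts), compound 1 gives 1.5 mg/kg. Compound 2 `CC(C)c1ccc(C2CN(C)Cc3c(N)cccc32)cc1` differs from it by a 43-fold higher number from compound 1 to compound 2 (1.64 log units; beyond the scatter), and in this assay compound 2 gives about 65 mg/kg. Compound 3 `CCCCOC(=O)Nc1cccc2c1CN(C)CC2c1ccccc1` carries a butoxycarbonyl group on the amine nitrogen of the core, and in this assay compound 3 gives 12 mg/kg. On these numbers compound 3 stands second highest of the three: its value is higher than that of compound 1 and lower than that of compound 2, both gaps beyond the scatter.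

Compound 4 `CC(C)NCCC(=O)Nc1cccc2c1CN(C)CC2c1ccccc1` is the next step from compound 3, with 2-(isopropylamino)ethyl in place of butoxy on a carbonyl carbon. Within the data shown here, of the measured steps, only the one from compound 1 to compound 2 is known in size, and it concerns a substituent on the aromatic ring, not the carbonyl side chain; it therefore bears only loosely on this change. Among the measured compounds shown here, no measured step at the carbonyl carbon is available. The authors therefore expect no more than a modest step in this assay from compound 3 to compound 4, a 1.3-fold higher number from compound 3 to compound 4 (0.10 log units; within the scatter), in either direction within or near the scatter. For compound 4 the estimate is 15 mg/kg, with a range from 5 mg/kg to 45 mg/kg.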

Compound 4, dose for half-maximal effect: about 200 mg/kg
Compound 4: middle estimate off by 13-fold (1.12 log units), on the low side, outside the stated range (above it).
By their numbers in this assay, from the lowest: compound 1; then compound 3; then compound 2; then compound 4.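

The carbonyl carbon of the side chain proves to be a sensitive place on the shared core: in this assay, exchanging butoxy for 2-(isopropylamino)ethyl gives a 17-fold higher number from compound 3 to compound 4 (1.22 log units; beyond the scatter). Within the data shown here, the earlier compounds offered only one step, a 43-fold higher number from compound 1 to compound 2 (1.64 log units; beyond the scatter), and it lay on an aromatic carbon, so this is the first sign that the side chain on the amide-type nitrogen can also shift the number by a large step. The exchange brings in a nitrogen and a hydrogen-bond donor that butoxy lacks, but no measurement shown here explains the size of the step.

Still open, from the compounds shown here alone, is whether the step follows from the nitrogen in the new chain or from the rest of the exchange, a question that a plain pentyl chain or a terminal carboxylic acid on the same carbonyl carbon could help to settle. Going by these compounds, it is equally open how the 2-(isopropylamino)ethyl side chain would read with chloro on the aromatic ring, the group that compound 1 carries.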